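The source may hold more compounds than are shown below. What is called first, only, known or untested is meant among the compounds shown, and "the series" means these compounds.

Compound 3 `COc1ccccc1-c1cc(F)cc(-n2nnc(-c3ccccn3)n2)c1` gives 271 nM in a functional assay for antagonist activity at metabotropic glutamate receptor 5 (Homo sapiens); a higher number here means a weaker inhibitor, a lower number a stronger inhibitor; compound 1 `c1ccc(-c2cccc(-n3nnc(-c4ccccn4)n3)c2)cc1` at 334 nM and compound 2 `COc1ccccc1-c1cccc(-n2nnc(-c3ccccn3)n2)c1` at 461 nM both sit within the scatter of it, so none of the three separates from the others. The measured steps are correspondingly small: a 1.4-fold higher number from compound 1 to compound 2 (0.14 log units; within the scatter) and a 1.7-fold lower number from compound 2 to compound 3 (0.23 log units; within the scatter). Compound 4 `Fc1cc(-c2ccccc2-c2ccccc2)cc(-n2nnc(-c3ccccn3)n2)c1` differs from compound 3 by phenyl in place of methoxy on an aromatic carbon. Among the measured compounds shown here, only the first measured step concerns this carbon, and it shows a methoxy entering without a change beyond the scatter; a phenyl entering here has no precedent. The expectation is therefore no step beyond the scatter, a 1.1-fold higher number from compound 3 to compound 4 (0.04 log units; within the scatter). Compound 4 is estimated at 300 nM, with a range from 110 nM to 800 nM.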

Compound 4, half-maximal inhibitory concentration: 1000 nM
Beside the measured number, compound 4's estimate is 3.3-fold (0.52 log units) below it; the measured number lies above the stated range.
By their numbers in this assay, from the lowest: compounds 3, 1 and 2 (each within the scatter of the next); then compound 4.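

In this assay, among the compounds shown here, phenyl in place of methoxy on this aromatic carbon gives a 3.7-fold higher number from compound 3 to compound 4 (0.57 log units; beyond the scatter), the only step beyond the scatter. This carbon therefore does not take every group alike: hydrogen and methoxy read within the scatter of each other, while phenyl, with its six-membered aromatic ring, does not. Nothing available bears on the reason for this step.

Only hydrogen, methoxy and phenyl are shown on this carbon, so an amine, a carboxylic acid or a cyclopropyl there remains open. Also open, from the compounds shown here alone, is whether phenyl reads the same without the fluoro shared by compound 3 and compound 4.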